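A Sulfonamide Replaces an Imine on a Shared Core

A few compounds are considered here, and "the series" means these few. Any claim that something is new, unique, unknown or untested is made for them only; others in the source may bear on it.

Compound 1 `N#CC1=C(/N=C/c2ccccc2)Oc2nc(Nc3ccc(S(N)(=O)=O)cc3)sc2C1c1ccc(Cl)cc1` — 45200 nM
Compound 2 `N#CC1=C(/N=C/c2ccc(Cl)cc2)Oc2nc(Nc3ccc(S(N)(=O)=O)cc3)sc2C1c1ccc(Cl)cc1` — 34600 nM

Of the compounds shown here, two have been tested in a functional assay on MCF7 cells (Homo sapiens) for antiproliferative activity, read by sulforhodamine B assay, with a stated time of 48 h; a higher number here means a weaker inhibitor, a lower number a stronger inhibitor. Compound 1 gives 45200 nM, and compound 2 gives 34600 nM. Going by the values given here, the single measured step, a 1.3-fold lower number from compound 1 to compound 2 (0.12 log units; within the scatter), puts chloro in place of hydrogen on an aromatic carbon and stays within the scatter. Among the compounds with values here, on these two numbers compound 2 stands at the lower one, with compound 1 as its only neighbour, and the two cannot be told apart.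

Compound 3 `Cc1ccc(S(=O)(=O)NC2=C(C#N)C(c3ccc(Cl)cc3)c3sc(Nc4ccc(S(N)(=O)=O)cc4)nc3O2)cc1` has not yet been measured. It differs from compound 2 in one place: a group of 11 heavy atoms (7 carbon, 1 nitrogen, 2 oxygen, 1 sulfur; one six-membered aromatic ring of carbon only) in place of a group of 9 heavy atoms (7 carbon, 1 nitrogen, 1 chlorine; one six-membered aromatic ring of carbon only), on a double-bonded ring carbon. Within the data shown here, no measured step touches this position; the one step known concerns a remote aromatic ring and was within the scatter, so it gives no direction for this change. The expected step is therefore a 1.2-fold lower number from compound 2 to compound 3 (0.06 log units; within the scatter), which is meant as no change beyond the scatter. The estimate for compound 3 is accordingly 30000 nM, within 10000 nM to 100000 nM, because compound 2 gives 34600 nM and nothing measured argues for a move from it.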

Compound 3, half-maximal inhibitory concentration: 71700 nM
For compound 3 the middle estimate is 2.4-fold (0.38 log units) below the measured one; measured number inside the range.
By their numbers in this assay, from the lowest: compounds 2, 1 and 3 (each within the scatter of the next, the first and the last beyond it).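

In this assay the position on the double-bonded ring carbon now has its first measured change, and swapping the imine of compound 2 for ((4-methylphenyl)sulfonyl)amino gives a 2.1-fold higher number from compound 2 to compound 3 (0.32 log units; beyond the scatter) as a modest step beyond the scatter. The same exchange made on the imine without the chloro gives a 1.6-fold higher number from compound 1 to compound 3 (0.20 log units; within the scatter) and stays within the scatter, so the size of the effect at this position depends on which imine serves as the reference, and the two readings together show only a small shift at most. Nothing available bears on what lies behind this shift.

The compounds shown hold only one group other than the imines at this carbon, so it remains open whether a free amine or an acetylamino group there would read any differently from ((4-methylphenyl)sulfonyl)amino. From the compounds shown here alone, it also remains open whether the methyl on that group's aromatic ring matters at all, which a phenylsulfonylamino or a methylsulfonylamino group at the same carbon would begin to settle.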